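This account rests on a few compounds, and the source may have more. Where it says the series, first, only, none or still open, it means among the compounds named here.

In a functional assay on A549 cells (Homo sapiens) for inhibition, read by MTT assay, with a stated time of 48 h (a higher number here means a weaker inhibitor, a lower number a stronger inhibitor), compound 1 `c1ccc(C(c2c[nH]c3ccccc23)c2c[nH]c3ccccc23)cc1` gives 40000 nM, the highest of the three numbers, while compound 2 `COc1ccc(C(c2c[nH]c3ccc(Br)cc23)c2c[nH]c3ccc(Br)cc23)cc1OC` gives 12000 nM and compound 3 `Brc1ccc(C(c2c[nH]c3ccc(Br)cc23)c2c[nH]c3ccc(Br)cc23)cc1` gives 5600 nM. Compound 4 `CC(c1ccccc1)(c1c[nH]c2ccccc12)c1c[nH]c2ccccc12` differs from compound 1 in one place: methyl in place of hydrogen on a saturated chain carbon bound to three aromatic carbons. For the measured compounds named here, the only measured single-place step, a 2.1-fold lower number from compound 2 to compound 3 (0.33 log units; beyond the scatter), is modest and exchanges one aryl group for another, so it bears only loosely. Going by the values given here, no measured step adds a methyl. No change beyond the scatter is therefore expected in this assay. The expected step is a 1.3-fold lower number from compound 1 to compound 4 (0.10 log units; within the scatter). Compound 4 is estimated at 32000 nM, with an expected range of 13000 nM to 80000 nM.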

Compound 4, half-maximal inhibitory concentration: 8500 nM
The estimate for compound 4 lay 3.8-fold (0.58 log units) above the measured number, outside the stated range (below it).
By their numbers in this assay, from the lowest: compounds 3, 4 and 2 (each within the scatter of the next, the first and the last beyond it); then compound 1.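

In this assay, the saturated chain carbon bound to three aromatic carbons responds to substitution: methyl in place of hydrogen gives a 4.7-fold lower number from compound 1 to compound 4 (0.67 log units; beyond the scatter). This step lies beyond the scatter, so one added carbon at this position is enough to lower the number in this series. From the compounds shown here alone, whether an ethyl group, a hydroxymethyl group or an amine at this carbon would extend, keep or reverse the step remains open, as does the effect of methyl here in the bromine-bearing compound 2 and compound 3. No measurement at hand explains the step from hydrogen to methyl.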